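The source may hold more compounds than are shown below. What is called first, only, known or untested is meant among the compounds shown, and "the series" means these compounds.

In a functional assay on A549 cells (Homo sapiens) for cytotoxicity (on this read-out higher numbers stand for an effect only at larger amounts of compound and lower numbers for an effect already at smaller amounts), compound 1 `COc1ccc(/C=C/c2cc(OC)c(OC(C)=O)c(OC)c2)cc1` gives 16.4 uM, the higher of the two actual numbers available. Compound 2 `COc1ccc(/C=C/c2cc(OC)c(OCc3ccccc3)c(OC)c2)cc1` gives > 25 uM, which is a limit of the assay and not a number. Compound 3 `COc1cc(/C=C\c2ccc(C(C)(C)C)cc2)cc(OC)c1OC` gives 1.02 uM, and its gap to compound 1 lies beyond the scatter.

Compound 4 `COc1ccc(/C=C\c2cc(OC)c(OC(C)=O)c(OC)c2)cc1` has not yet been measured. It relates to compound 1 through the two compounds have the same atoms and bonds and differ only in configuration as drawn: 1 of 1 stereo elements differ; a double bond is drawn E in compound 1 and Z in compound 4: the two compounds have the same atoms and bonds, and a double bond is drawn E in compound 1 and Z in compound 4. Within the data shown here, the one measured single-place step, an at least 1.5-fold higher number from compound 1 to compound 2 (0.18 log units; that floor lies within the scatter), puts benzyl in place of acetyl on an oxygen on an aromatic ring. It leaves the double bond as drawn and its floor lies within the scatter, so it gives no size for this change.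

Among the measured compounds shown here, no measured pair isolates the configuration of the double bond. For the measured compounds named here, the only guide is compound 3 at 1.02 uM, the one measured compound drawn Z, although its structure also differs from compound 1 elsewhere. A clear move towards a lower number in this assay is therefore expected, with wide uncertainty. The expected change is a 6.6-fold lower number from compound 1 to compound 4 (0.82 log units; beyond the scatter). For compound 4 the estimated value is 2.5 uM, expected to lie between 0.3 uM and 15 uM.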

Compound 4, concentration for half-maximal effect: 21.5 uM
Compound 4: the middle estimate sits 8.6-fold (0.93 log units) below what was measured; measured number above the stated range.
By their numbers in this assay, from the lowest: compound 3; then compounds 1 and 4 (each within the scatter of the next). At a limit, above all of these: compound 2.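

In this assay, among these compounds, the configuration of the double bond is isolated for the first time, and the step reads a 1.3-fold higher number from compound 1 to compound 4 (0.12 log units; within the scatter), so with the acetyl group in place the E and Z forms cannot be told apart on this read-out. Among the compounds shown here, this pair gives a direct reading of the double bond, which no earlier pair could, and that reading rests on one fact: the fact that compounds 1 and 4 differ only in the configuration as drawn Compound 3 gives 1.02 uM, but the pair shows that a Z double bond does not by itself bring such a value on the core of compound 1.

Compound 3 differs from compound 4 in more than one place, so the compounds shown do not say which of those places goes with its value, nor whether the configuration of the double bond would count with a free hydroxyl or an amine in place of the acetyl-bearing oxygen. Compound 2 is known only through a limit, so the size of the benzyl step stays open as well: the limit of > 25 uM in this assay, at which 1 of the 4 values shown sits.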